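Removing the Ring Phenyl from an Imide Nitrogen

This account rests on a few compounds, and the source may have more. Where it says the series, first, only, none or still open, it means among the compounds named here.

Compound 1 `Cn1cc(C2=C(c3nn(CCCn4ccnc4)c4ncccc34)C(=O)N(c3ccccc3)C2=O)c2ccccc21` carries a phenyl on an amide-type nitrogen in a ring, and in a functional assay on A549 cells (Homo sapiens) for antiproliferative activity, read by MTT assay, with a stated time of 48 h (on this read-out lower numbers stand for stronger inhibition and higher numbers for weaker inhibition), compound 1 gives 1560 nM. Compound 2 `Cn1cc(C2=C(c3nn(CCCn4ccnc4)c4ncccc34)C(=O)NC2=O)c2ccccc21` differs from compound 1 only by hydrogen in place of phenyl on an amide-type nitrogen in a ring. In this assay compound 2 reaches only a limit, > 100000 nM, which is not a number. The step is therefore an at least 64-fold higher number from compound 1 to compound 2 (1.80 log units; beyond the scatter), a step whose size is bounded by the limit of > 100000 nM in this assay, at which 1 of the 3 values shown sits.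

Compound 3 `CN(C)CCCn1nc(C2=C(c3cn(C)c4ccccc34)C(=O)N(c3ccccc3)C2=O)c2cccnc21` shares the phenyl-bearing imide of compound 1 but differs in its core by dimethylamino in place of 1H-imidazol-1-yl on a saturated chain carbon, three bonds along the chain from an aromatic nitrogen. In this assay compound 3 gives 13000 nM, and the step is an 8.3-fold higher number from compound 1 to compound 3 (0.92 log units; beyond the scatter).

Compound 4 `CN(C)CCCn1nc(C2=C(c3cn(C)c4ccccc34)C(=O)NC2=O)c2cccnc21` has not been measured. It differs from compound 3 by hydrogen in place of phenyl on an amide-type nitrogen in a ring, the same change, at the same place, that separates compound 2 from compound 1. With compound 3 already the higher of the two measured numbers, the expected step from compound 3 to compound 4 in this assay is estimated to be a 31-fold higher number from compound 3 to compound 4 (1.49 log units; beyond the scatter), resting on the step of an at least 64-fold higher number from compound 1 to compound 2 (1.80 log units; beyond the scatter) seen for the identical change. Compound 4 is thus expected to give about 400000 nM, most likely returned only as a limit, with an estimated range from 80000 nM to 3000000 nM.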

Compound 4, half-maximal inhibitory concentration: > 100000 nM
Compound 4 gave a limit, no number; the forecaster's own chance of this, stated with the estimate: 85%; the middle value is on the limit's open side.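

In this assay compound 4 gives > 100000 nM, which is a limit and not a number. Hydrogen in place of phenyl on the amide-type nitrogen therefore moves the result in the same direction on the second core as on the first, with an at least 7.6-fold higher number from compound 3 to compound 4 (0.88 log units; beyond the scatter), and on both cores the compound lacking the phenyl ends at the same limit: the limit of > 100000 nM in this assay, at which 2 of the 4 values shown sit. The direction of the change thus carries from one core to the other, but its size does not transfer in any readable way, and the step between compound 2 and compound 4 cannot be read either, since both ends of it are limits: the same change on two cores in this assay, an at least 64-fold higher number (1.80 log units; beyond the scatter) from compound 1 to compound 2 and an at least 7.6-fold higher number (0.88 log units; beyond the scatter) from compound 3 to compound 4; the limit leaves it open whether they differ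

The compounds shown leave open whether any other group on that nitrogen, such as methyl, benzyl or a chlorophenyl, would keep a measurable number in this assay, and so how much of the phenyl is actually needed. They also leave open how a morpholine or a piperazine in place of dimethylamino, or a longer chain, would compare, since the exchange of the chain-end groups is readable only with the phenyl present, as an 8.3-fold higher number from compound 1 to compound 3 (0.92 log units; beyond the scatter).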